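This account rests on a few compounds, and the source may have more. Where it says the series, first, only, none or still open, it means among the compounds named here.

Compound 1 `CN1N=C(c2ccc(N)cc2)CCC1=O` and compound 2 `CC(=O)Nc1ccc(C2=NN(C)C(=O)CC2)cc1` share one core and differ in a single place, by acetyl in place of hydrogen on a nitrogen on an aromatic ring. In a functional assay for inhibition, with Homo sapiens as the target (a higher number here means that more compound is needed for the effect, a lower number that less compound is needed), compound 1 gives only a limit of the assay, > 46.4 ug/mL. In this assay compound 2 likewise gives only a limit, > 46.4 ug/mL. The step that the two limits leave unreadable from compound 1 to compound 2 therefore has no readable size. Compound 3 `Nc1cccc(C2=NNC(=O)CC2)c1` rests on a second core; the difference between the two cores is not broken down here. In this assay compound 3 also gives only a limit, > 46.4 ug/mL. Compound 4 `CC(=O)Nc1cccc(C2=NNC(=O)CC2)c1` has not yet been measured in this assay. It differs from compound 3 by acetyl in place of hydrogen on a nitrogen on an aromatic ring, the same change as from compound 1 to compound 2, made at a place that is described in the same words. Within the data shown here, because the limit of > 46.4 ug/mL in this assay, at which 3 of the 3 values shown sit, holds every value so far, the step from compound 3 to compound 4 is expected to be a step that the limit leaves unreadable from compound 3 to compound 4 at most in this assay, with a limit the most likely outcome. Compound 4 is thus estimated at 60 ug/mL in this assay, between 25 ug/mL and 200 ug/mL.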

Compound 4, half-maximal effective concentration: > 46.4 ug/mL
Compound 4: only a limit was reported; the forecaster's own chance of this, stated with the estimate: 85%; the middle value does not contradict the limit.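

In this assay compound 4 gives > 46.4 ug/mL, which is only a limit. Among these compounds, compound 3 also gives only a limit, so no step from compound 3 to compound 4 can be read. The compounds shown leave open what amino to acetamido does to the effect, and at what concentration any of them acts, with all values resting on one limit: the limit of > 46.4 ug/mL in this assay, at which 4 of the 4 values shown sit.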